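The source may hold more compounds than are shown below. What is called first, only, known or untested is meant among the compounds shown, and "the series" means these compounds.

Three compounds from this series have been examined in a functional assay on HL-60 cells (Homo sapiens) for inhibition, read by MTT assay, with a stated time of 72 h; on this read-out higher numbers stand for weaker inhibition and lower numbers for stronger inhibition. Compound 1 `COc1cccc(N2CCN(C(=O)c3oc(C(F)(F)F)nc3-c3cccc(F)c3)CC2)c1` is recorded in this assay as "not active" (no number reported). Compound 2 `O=C(c1oc(C(F)(F)F)nc1-c1ccccc1F)N1CCN(c2cccc(Cl)c2)CC1` is recorded in this assay as "not active" (no number reported). Within the data shown here, compound 3 `Cc1nc(-c2ccccc2)c(C(=O)N2CCN(c3ccccc3Cl)CC2)o1` is the only member for which a number exists: in this assay compound 3 gives 124 nM. Compound 3 therefore stands alone on the numbers shown, and no measured neighbor is available against which a step could be read.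

Compound 4 `COc1cc(OC)cc(N2CCN(C(=O)c3oc(C)nc3-c3ccccc3)CC2)c1` has not yet been measured in this assay. It differs from compound 3 in one place, and the counted change is 3,5-dimethoxyphenyl in place of 2-chlorophenyl on an amine nitrogen in a ring. Among the measured compounds shown here, since no step between measured compounds is known, the size and direction of this change can only be expected, not read. For the measured compounds named here, the two compounds without a number, compound 1 and compound 2, both carry aryl groups on the ring nitrogen that differ from the one in compound 3, which gives some reason to expect a loss rather than a gain when the aryl group is exchanged. Compound 4 is accordingly expected to give about 450 nM in this assay, within a range from 120 nM to 3000 nM. This expectation means a step of a 3.6-fold higher number from compound 3 to compound 4 (0.56 log units; beyond the scatter), a weakening somewhat beyond the scatter, though a result within the scatter cannot be excluded.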

Compound 4, half-maximal inhibitory concentration: 19.2 nM
Estimate against measurement, compound 4: 23-fold (1.37 log units) above; the measured number lies below the stated range.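

In this assay the exchange of 2-chlorophenyl for 3,5-dimethoxyphenyl on the amine nitrogen in the ring gives a 6.5-fold lower number from compound 3 to compound 4 (0.81 log units; beyond the scatter), so the number at this position responds to the aryl group, and here it moves toward stronger inhibition even though the entering group is larger by the count of heavy atoms and brings two hydrogen-bond acceptors. Among these compounds, this is the first step that can be read at this position: compound 1 and compound 2 carry no number and differ from compound 3 in more than one place, so no step can be read from either of them, and their lack of activity says nothing on its own about the aryl group. Nothing available accounts for the lower number of compound 4.

This single step cannot separate the departure of the chlorine from the arrival of the two methoxy groups. The compounds shown also leave open how an unsubstituted phenyl, or a 3,5-dihydroxyphenyl carrying hydroxy groups in place of the methoxy groups, would read at this same nitrogen on the core of compound 3.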